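From carboxy to carbamoyl in the compound 1 series

The source may report more compounds than this note shows. Statements on the series, on what has been measured and on what is new or still open speak of the compounds shown alone.

Among the compounds with values here, in a functional assay for inhibition, with Homo sapiens as the target (a lower number here means a stronger inhibitor, a higher number a weaker inhibitor), compound 1 (`O=C(O)CCCCCCCCn1nc(-c2ccccc2)c(-c2ccccc2)c1-c1ccccc1`) gives 400 nM and holds the lowest number of the three measured so far. Compound 3 (`O=C(O)CCCCCCCCn1cc(-c2ccccc2)c(-c2ccccc2)n1`) comes nearest at 4500 nM in this assay with hydrogen in place of phenyl on an aromatic carbon, and the change is an 11-fold higher number from compound 1 to compound 3 (1.05 log units; beyond the scatter) as a step. Compound 2 (`CCc1c(-c2ccccc2)nn(CCCCCCCCC(=O)O)c1-c1ccccc1`) reads > 79000 nM in this assay and this is a limit of the assay, not a number. Ethyl in place of phenyl on an aromatic carbon thus gives an at least 190-fold higher number from compound 1 to compound 2 (2.29 log units; beyond the scatter) as a step.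

The change to compound 4 (`NC(=O)CCCCCCCCn1nc(-c2ccccc2)c(-c2ccccc2)c1-c1ccccc1`) is amino in place of hydroxy on a carbonyl carbon and reads in words as amino in place of hydroxy on a carbonyl carbon, or carboxy to carbamoyl. Within the data shown here, neither measured step touches the carboxy group, so this change has no direct precedent. Both steps bear on it only indirectly, showing that single changes to compound 1 have so far cost much, with an 11-fold higher number from compound 1 to compound 3 (1.05 log units; beyond the scatter) as the smaller loss. A large step towards a higher number in this assay is therefore expected, though with wide uncertainty. The estimate amounts to a 30-fold higher number from compound 1 to compound 4 (1.48 log units; beyond the scatter) as an expected step. For compound 4 the estimated value is 12000 nM with an expected range of 1500 nM to 70000 nM in this assay for now.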

Compound 4, half-maximal inhibitory concentration: 33000 nM
For compound 4 the middle estimate is 2.8-fold (0.44 log units) below the measured one; the range from low to high includes it.
By their numbers in this assay, from the lowest: compound 1; then compound 3; then compound 4. At a limit, above all of these: compound 2.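

Amino in place of hydroxy on the carbonyl carbon gives an 83-fold higher number from compound 1 to compound 4 (1.92 log units; beyond the scatter) in this assay, the first read-out of a change at this carbonyl carbon. The computed hydrogen-bond donor and acceptor counts and the net charge of the leaving and entering groups are the same, so those counts do not separate compound 1 from compound 4, yet the assay does. Within the data shown here, all three single changes to compound 1 now give a higher number, with none going against this, so the carbonyl carbon joins the aromatic carbons as a place where the series loses ground, and compound 2 remains the only compound at a limit of the assay, which is not a number: the limit of > 79000 nM in this assay, at which 1 of the 4 values shown sits.

Still open, from the compounds shown here alone, is whether the loss follows from removing the hydroxy group or from any replacement of the carboxylic acid, which a methyl ester, a hydroxamic acid or a tetrazole at the chain end would help to separate. The compounds shown also leave open how the carboxylic acid interacts with chain length, which a shorter or longer chain on the core of compound 1 would test.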